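Aryl swap on the shared core: cytotoxicity notes

A few compounds are considered here, and "the series" means these few. Any claim that something is new, unique, unknown or untested is made for them only; others in the source may bear on it.

Values below come from an ADME assay on HEL cells (Homo sapiens) for cytotoxicity, with a stated time of 3 days; on this read-out lower numbers stand for higher toxicity in this test and higher numbers for lower toxicity in this test.

compound 1 `Cc1cc(-c2cccc(F)c2)c2ncc(CSCCc3ccccc3)n2c1`: 20 ug/mL
compound 2 `Cc1cc(-c2ccccc2)cn2c(CSCCc3ccccc3)cnc12`: 20 ug/mL
compound 3 `Cc1cc(-c2ccsc2)cn2c(CSCCc3ccccc3)cnc12`: >= 4 ug/mL

Compound 1 stands level with compound 2 at the digits shown, within the scatter of this assay; neither can be called more or less toxic than the other. The value of compound 3 is a limit of this assay and not a number. As a result a step that the limit leaves unreadable from compound 2 to compound 3 stays unreadable, as does the size of any effect of thiophen-3-yl in place of phenyl on an aromatic carbon (the limit of >= 4 ug/mL in this assay, at which 1 of the 3 values shown sits).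

Compound 4 `Cc1cc(-c2cccs2)c2ncc(CSCCc3ccccc3)n2c1` is the next member. Against compound 1 the change is thiophen-2-yl in place of 3-fluorophenyl on an aromatic carbon. Within the data shown here, the only measured step that touches the aryl group is the one from compound 2 to compound 3, and it gives neither a size nor a direction. No step beyond the scatter can therefore be predicted for this assay; the expectation rests on compound 1 at 20 ug/mL with a wide range to cover the unreadable step. Compound 4 is expected to show about 20 ug/mL in this assay, between 5 ug/mL and 50 ug/mL. The expected step is no change at the digits printed from compound 1 to compound 4 (within the scatter), and a limit rather than a number is a real possibility.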

Compound 4, minimum cytotoxic concentration: 100 ug/mL
Compound 4: the middle estimate sits 5.0-fold (0.70 log units) below what was measured; measured number outside the range, above it.
By their numbers in this assay, from the lowest: compounds 1 and 2 (each within the scatter of the next); then compound 4.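

In this assay the series now has its first readable aryl step at this position, meta to a methyl group: a 5.0-fold higher number from compound 1 to compound 4 (0.70 log units; beyond the scatter), for thiophen-2-yl in place of 3-fluorophenyl on an aromatic carbon. The step runs towards lower toxicity in this test, so the read-out at this position does depend on the aryl group it carries, although the change replaces a six-membered carbon ring bearing fluorine with a five-membered ring holding one sulfur, and this single step cannot separate those differences. Compound 3 stands at a limit, so its step from compound 2 still cannot be read: the limit of >= 4 ug/mL in this assay, at which 1 of the 4 values shown sits.

On these data alone, it remains open whether a pyridin-3-yl ring or an aryl group carrying an amine or a carboxylic acid at this position would read closer to thiophen-2-yl or to 3-fluorophenyl. Also open, as far as these compounds go, is how a shorter or longer side chain on the shared core would shift the read-out, and whether the step seen here would persist with such a chain.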